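Demethylation of the sulfone: a step toward compound 3

The compounds below may be only part of what the source reports. "The series", "measured", "known", "first", "only" and "open" are said of these compounds alone.

Measured compounds:
compound 1, `Clc1ccc2[nH]cc(SC3CCNCC3)c2c1`, 0.3 mg/kg
compound 2, `CN1CCC(S(=O)(=O)c2c[nH]c3ccc(Cl)cc23)CC1`, 5.4 mg/kg

In a functional assay on the whole organism with Mus musculus as the target, in the writhing test (a higher number here means that more compound is needed for the effect, a lower number that less compound is needed), compound 2 stands with the higher of the two numbers, and compound 1 with the lower; the gap between them is wider than the usual scatter of this assay. Among the measured compounds shown here, the two compounds differ in more than one place, so no single step between them can be read off, and the data only show that compound 1 needs far less compound than compound 2 for the half-maximal effect.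

Compound 3, `O=S(=O)(c1c[nH]c2ccc(Cl)cc12)C1CCNCC1`, is not yet measured. It differs from compound 2 in one place only: hydrogen in place of methyl on an amine nitrogen in a ring. The ring amine of compound 3 thus carries hydrogen, as in compound 1, while the sulfone of compound 2 is kept.

Given that compound 1 gives 0.3 mg/kg with the hydrogen-bearing amine, compound 3 is expected to move toward a lower number, with a step from compound 2 estimated as a 2.7-fold lower number from compound 2 to compound 3 (0.43 log units; beyond the scatter). The value for compound 3 is estimated at 2 mg/kg, with a range from 0.5 mg/kg to 8 mg/kg.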

Compound 3, dose for half-maximal effect: 12.5 mg/kg
Compound 3: the middle estimate sits 6.3-fold (0.80 log units) below what was measured; measured number outside the range, above it.
By their numbers in this assay, from the lowest: compound 1; then compound 2; then compound 3.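

In this assay, the exchange of methyl for hydrogen on the amine nitrogen in the ring, with the sulfone kept, gives a 2.3-fold higher number from compound 2 to compound 3 (0.36 log units; beyond the scatter) and so is a modest step, the first that can be read at this position; among the sulfones shown, the methyl-bearing amine is the one that needs less compound. The earlier pair could not show this, and the new result also means that a hydrogen on this amine does not by itself go with a low number: compound 1 gives 0.3 mg/kg with that hydrogen, and compound 3 gives 12.5 mg/kg with the same hydrogen and a sulfone. Nothing at hand bears on why the step runs in this direction.

The compounds shown leave open whether the same exchange would run the same way in the thioether, since a methyl on the amine nitrogen appears only together with the sulfone. They also leave open how an ethyl or benzyl group on that nitrogen, or a sulfoxide in place of the sulfone, would stand in this test.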